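Series notes: indole-triazole piperidines at the serotonin 1D site

The source may hold more compounds than are shown below. What is called first, only, known or untested is meant among the compounds shown, and "the series" means these compounds.

Measured so far:
compound 1, `CC(=O)Nc1ccc([C@H](C)NCC2CCN(CCCc3c[nH]c4ccc(-n5cnnc5)cc34)CC2)cc1`: 0.6 nM
compound 2, `CC(C)=CCCN(C)C1CCN(CCCc2c[nH]c3ccc(-n4cnnc4)cc23)CC1`: 2.6 nM

Two compounds share the core shown above and have been tested in an assay on CHO cells for displacement of a labelled ligand from 5-hydroxytryptamine receptor 1D (Homo sapiens); a lower number here means a stronger inhibitor, a higher number a weaker inhibitor. Compound 2 gives 2.6 nM, the higher of the two numbers; its nearest neighbour is compound 1, whose number is lower by a margin beyond the usual scatter. Going by the values given here, no pair of measured compounds differs in a single place, so no step between measured compounds can be read off.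

Compound 3, `C[C@@H](NCC1CCN(CCCc2c[nH]c3ccc(-n4cnnc4)cc23)CC1)c1ccccc1`, is not yet measured. Relative to compound 2 the change is ((1-phenylethyl)amino)methyl in place of methyl(4-methylpent-3-en-1-yl)amino on a saturated ring carbon. The side chain that enters brings an aromatic ring and a hydrogen-bond donor, which the leaving chain lacks.

Among the compounds with values here, with only two values, the expectation for the step of a 2.6-fold lower number from compound 2 to compound 3 (0.41 log units; beyond the scatter) is a move to a lower number, modest in size and near the edge of the scatter, because compound 2 sits at 2.6 nM and the rest of the molecule is unchanged. Compound 3 is accordingly estimated at 1 nM, with a range of 0.3 nM to 3 nM.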

Compound 3, half-maximal inhibitory concentration: 1.4 nM
Compound 3: the middle estimate sits 1.4-fold (0.15 log units) below what was measured; low and high end bracket the measured number.
By their numbers in this assay, from the lowest: compound 1; then compounds 3 and 2 (each within the scatter of the next).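

In this assay, ((1-phenylethyl)amino)methyl in place of methyl(4-methylpent-3-en-1-yl)amino on the saturated ring carbon gives a 1.9-fold lower number from compound 2 to compound 3 (0.27 log units; within the scatter), so this position tolerates a side chain with an aromatic ring and one without, and compound 2 and compound 3 cannot be told apart. The acetamido group does register: 1-phenylethyl in place of 1-(4-acetamidophenyl)ethyl on the amine nitrogen gives a 2.3-fold higher number from compound 1 to compound 3 (0.37 log units; beyond the scatter), a modest step. No measurement available here explains either step.

Open, from the compounds shown here alone, is whether other groups on that aromatic ring, such as a methoxy group or a carboxylic acid, would match the acetamido group. Also open, going by these compounds, are the opposite configuration at the stereocentre and a methyl group on the amine nitrogen of compound 3.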